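The source may hold more compounds than are shown below. What is called first, only, known or untested is meant among the compounds shown, and "the series" means these compounds.

Working notes on the series.

All three measured compounds share one core, first seen in compound 1 `CCCCNC(=O)Oc1cccc(-n2ccc(C(N)=O)c2)c1`. In an assay (brain) for inhibition of Fatty-acid amide hydrolase 1 (Mus musculus), with stated times of 20 min and 15 min (a higher number here means a weaker inhibitor, a lower number a stronger inhibitor), compound 1 gives 240 nM. Compound 2 `C#CCCCCCCCCCOC(=O)c1ccn(-c2cccc(OC(=O)NCCCC)c2)c1` carries a long ester chain on the shared core. For compound 2 this assay returns only a limit, > 70 nM, and not a number. Compound 3 `O=C(NC1CCCCC1)Oc1cccc(-n2ccc(C(=O)OCCCCCCc3ccccc3)c2)c1` likewise returns only a limit in this assay, > 50000 nM. Two of the three values shown are thus limits (the limit of > 50000 nM in this assay, at which 1 of the 3 values shown sits, (the limit of > 70 nM in this assay, at which 1 of the 3 values shown sits)), and compound 2 cannot be placed against compound 1 beyond what the sign of its limit allows.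

Compound 4 `C#CCCCCCCCCCOC(=O)c1ccn(-c2cccc(OC(=O)NCCCCCCc3ccccc3)c2)c1` differs from compound 2 by phenethyl in place of hydrogen on a saturated chain carbon, four bonds along the chain from an amide-type nitrogen; cut one bond further out, the difference reads propyl to 5-phenylpentyl. Within the data shown here, no step between measured compounds matches this change, so its size cannot be read from the data. Among the measured compounds shown here, the only measured compound with a long aryl-tipped chain, compound 3, sits at a limit in this assay. A weakening step is therefore expected from compound 2 to compound 4, a step that the limit leaves unreadable from compound 2 to compound 4, with wide uncertainty. Compound 4 is expected to give about 2000 nM in this assay, within 100 nM to 50000 nM, and a limit rather than a number remains a real possibility.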

Compound 4, half-maximal inhibitory concentration: > 200 nM
Compound 4 was reported as a limit; the forecaster's own chance of this, stated with the estimate: 40%; the middle value is on the limit's open side.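

Among these compounds, compound 2 and compound 4 both return only limits in this assay, so no step between them can be read. The compounds shown leave open how far, and in which direction, phenethyl in place of hydrogen on the saturated chain carbon moves inhibition.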